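The source may hold more compounds than are shown below. What is called first, only, known or untested is meant among the compounds shown, and "the series" means these compounds.

Compound 2 `CCOC(=O)CCCCCOc1cccc(CN(C(=O)c2ccc(-c3cccc4ccccc34)cc2)C(C)C)c1` stands at a limit in an ADME assay on HepG2 cells (Homo sapiens) for cytotoxicity, read by CellTiter-Glo and resazurin assay, with a stated time of 72 h; a lower number here means that less compound is needed, a higher number that more compound is needed for the effect: compound 2 gives > 26000 nM, which is a limit of the assay and not a number. Compound 1 `CCOC(=O)CCCCCOc1cccc(CN(C(=O)c2ccc(-c3cccc(N(C)C)c3)cc2)C(C)C)c1` likewise reaches only a limit, giving in this assay > 26000 nM. The step that the two limits leave unreadable from compound 1 to compound 2 is therefore unreadable. Compound 3 `CCOC(=O)CCCCCOc1cccc(CN(C(=O)c2ccc(-c3cccc(NC(C)=O)c3)cc2)C(C)C)c1` carries 3-acetamidophenyl in place of naphthalen-1-yl on an aromatic carbon. Among the measured compounds shown here, the only measured step at this position gives no size, since the limit of > 26000 nM in this assay, at which 2 of the 2 values shown sit, holds both values shown. No shift beyond the scatter is expected, and the expected step is a step that the limit leaves unreadable from compound 2 to compound 3. Compound 3 is estimated at 40000 nM, within 20000 nM to 100000 nM, most probably again reported as a limit.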

Compound 3, half-maximal effective concentration: > 26000 nM
Compound 3: only a limit was reported (the forecaster's own chance of this, stated with the estimate: 85%); the middle value does not contradict the limit.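

No new step can be read between compound 1, compound 2 and compound 3 in this assay: the limit of > 26000 nM in this assay, at which 3 of the 3 values shown sit.

Still open, going by these compounds, is how far each compound's true value lies from this limit, and so whether these groups differ at all here.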